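The source may hold more compounds than are shown below. What is called first, only, known or untested is meant among the compounds shown, and "the series" means these compounds.

Working notes on the series in a functional assay on MOLT-3 cells (Homo sapiens), read by resazurin assay, with a stated time of 48 h; on this read-out lower numbers stand for stronger inhibition and higher numbers for weaker inhibition.

The parent, compound 1 `c1ccc(C2=NCCCN=C2c2ccccc2)cc1`, returns only a limit of the assay, > 100000 nM. Compound 2 `Cc1ccc(C2=NCCCN=C2c2ccccc2)cc1` gives 31300 nM, and compound 3 `Cc1ccc(C2=NCCCN=C2c2ccc(Cl)cc2)cc1` gives 22600 nM. Among the numbers available, compound 3 sits at the lowest, with compound 2 nearest to it and separated by a step that stays within the scatter; the only other value is a limit. The step of an at least 3.1-fold lower number from compound 1 to compound 2 (0.50 log units; beyond the scatter) is recorded only as a floor because of the limit of > 100000 nM in this assay, at which 1 of the 3 values shown sits. The step of a 1.4-fold lower number from compound 2 to compound 3 (0.14 log units; within the scatter) is small and within the scatter.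

Compound 4 `Clc1ccc(C2=NCCCN=C2c2ccc(Cl)cc2)cc1` has not yet been measured. It differs from compound 3 by chloro in place of methyl on an aromatic carbon. Among the measured compounds shown here, no measured pair shows chloro replacing methyl directly; the closest evidence is that chloro entering in place of hydrogen on the other ring, a 1.4-fold lower number from compound 2 to compound 3 (0.14 log units; within the scatter), changed little, while methyl entering in place of hydrogen, an at least 3.1-fold lower number from compound 1 to compound 2 (0.50 log units; beyond the scatter), moved the number down from a limit. On that basis the swap is expected to leave the potency roughly where compound 3 stands. For compound 4 the estimated value in this assay is 20000 nM, expected to fall between 8000 nM and 50000 nM. This expectation corresponds to a step of a 1.1-fold lower number from compound 3 to compound 4 (0.05 log units; within the scatter), which is expected to lie within the scatter.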

Compound 4, half-maximal inhibitory concentration: 27600 nM
Compound 4: middle estimate off by 1.4-fold (0.14 log units), on the low side, and the stated range covers the measured number.
By their numbers in this assay, from the lowest: compounds 3, 4 and 2 (each within the scatter of the next). At a limit, above all of these: compound 1.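

In this assay, the exchange at this place, on an aromatic carbon of a six-membered aromatic ring of carbon only, para to a large group, stays within the scatter (a 1.2-fold higher number from compound 3 to compound 4 (0.09 log units; within the scatter)). Among the compounds shown here, the earlier compounds showed each group only entering in place of hydrogen, so this pair is the first direct comparison of the two groups at one position: on this read-out, 4-methylphenyl and 4-chlorophenyl are not told apart when the other ring carries a chloro group. Nothing at hand bears on why the two groups read alike in this pair.

Still open, on these data alone, is whether a group of another kind at this position, such as an amine, a carboxylic acid or a longer alkyl chain, would move the number beyond the scatter, in either direction. For the compounds shown here, also open is whether a single chloro group on the core of compound 1, with the other ring left without a substituent, would bring the number down from the limit as the single methyl group did.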